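This account rests on a few compounds, and the source may have more. Where it says the series, first, only, none or still open, it means among the compounds named here.

Compound 2, `Cc1cc(NC(=O)Nc2cccc(OC(F)(F)F)c2)c2ccccc2n1`, is a urea built on the shared core, and in an ADME assay on HepG2 cells (Homo sapiens) for cytotoxicity, with a stated time of 72 h (a higher number here means that more compound is needed for the effect, a lower number that less compound is needed), compound 2 gives 13000 nM. Among the measured compounds shown here, the only other measured compound, compound 1, `Cc1cc(NC(=O)Nc2ccc(F)c(F)c2)c2ccccc2n1`, gives 21000 nM in this assay; the two numbers lie within the scatter of each other, so compound 2 holds the lower of the two values without being set apart from compound 1.

Compound 3, `Cc1cc(NC(=O)Nc2cccc(F)c2)c2ccccc2n1`, differs from compound 2 by fluoro in place of trifluoromethoxy on an aromatic carbon. For the measured compounds named here, no pair of measured compounds shows this particular change, so its effect has to be judged from the two numbers at hand. Compound 1 with its different aryl substitution gives 21000 nM, and compound 2 with 13000 nM sits close by, which suggests the readout is not very sensitive to variation on this ring. The expected step is a 1.3-fold higher number from compound 2 to compound 3 (0.12 log units; within the scatter), not beyond the scatter. Compound 3 is therefore expected to give 17000 nM, within a range from 8000 nM to 36000 nM.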

Compound 3, half-maximal effective concentration: > 25000 nM
Compound 3 gave a limit, no number; the forecaster's own chance of this, stated with the estimate: 10%; at least 1.4-fold (0.16 log units) between middle value and limit.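

In this assay compound 3 gives > 25000 nM, which is a limit of the assay and not a number. Read against it, fluoro in place of trifluoromethoxy on this aromatic carbon gives an at least 1.9-fold higher number from compound 2 to compound 3 (0.28 log units; that floor lies within the scatter), and hydrogen in place of fluoro on an aromatic carbon gives an at least 1.1-fold higher number from compound 1 to compound 3 (0.07 log units; that floor lies within the scatter), so both changes now have a floor, though neither floor clears the scatter and the true size of either step stays unknown. The result also marks where the read-out ends, which the earlier compounds did not reach: the limit of > 25000 nM in this assay, at which 1 of the 3 values shown sits.

The compounds shown leave open what an amine or a carboxylic acid on this aromatic carbon would give, and whether chloro in place of fluoro would return a number rather than a limit. They also leave open how far past its limit compound 3 lies.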